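The source may hold more compounds than are shown below. What is called first, only, known or untested is meant among the compounds shown, and "the series" means these compounds.

In a functional assay on MT4 cells (Homo sapiens) for cytotoxicity, read by MTT assay, with a stated time of 5 days (a higher number here means that more compound is tolerated, a lower number that less compound is tolerated), compound 2 `N#Cc1ccc(Nc2nccc(Oc3ccc(-c4ccc(C#N)cc4)c(Cl)c3)n2)cc1` is the only one of the three measured compounds to return a number, giving 31100 nM. Compound 1 `N#Cc1ccc(Nc2nccc(Oc3ccc(-c4ccc(C#N)cc4)c(F)c3)n2)cc1` reaches only the limit of the assay, > 307000 nM, and no number is known for it. Compound 3 `COc1cc(Oc2ccnc(Nc3ccc(C#N)cc3)n2)ccc1-c1ccc(C#N)cc1` likewise stops at the limit, > 298000 nM. The step of an at least 9.8-fold lower number from compound 1 to compound 2 (0.99 log units; beyond the scatter) is an exchange of chloro for fluoro on an aromatic carbon; the step of an at least 9.5-fold higher number from compound 2 to compound 3 (0.98 log units; beyond the scatter) is an exchange of methoxy for chloro, also on an aromatic carbon; the step that the two limits leave unreadable from compound 1 to compound 3 runs between two limits and gives no size.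

Compound 4 `Cc1cc(-c2ccc(C#N)cc2)c(Cl)cc1Oc1ccnc(Nc2ccc(C#N)cc2)n1` differs from compound 2 by methyl in place of hydrogen on an aromatic carbon. Within the data shown here, none of the measured steps touches this change: all three vary the fluoro, chloro or methoxy group, while the aromatic carbon that receives the methyl keeps its hydrogen throughout compounds 1 to 3. Among the measured compounds shown here, with no measured step to lean on, the change is expected to stay within the scatter of this assay, neither clearly higher nor clearly lower. Compound 4 is therefore estimated at 40000 nM, between 15000 nM and 120000 nM. That expectation means a step of a 1.3-fold higher number from compound 2 to compound 4 (0.11 log units; within the scatter).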

Compound 4, half-maximal cytotoxic concentration: > 285000 nM
Compound 4: no number, only a limit; the forecaster's own chance of this, stated with the estimate: 20%; middle value at least 7.1-fold (0.85 log units) from the limit.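

In this assay, placing methyl instead of hydrogen on the aromatic carbon that is ortho to a large group, meta to a 4-cyanophenyl group and para to a chloro group gives an at least 9.1-fold higher number from compound 2 to compound 4 (0.96 log units; beyond the scatter). This shows that the read-out responds to this position as well: compounds 1 to 3 kept their hydrogen here and varied only the fluoro, chloro or methoxy group, whereas compound 4 keeps the chloro group of compound 2 and still tolerates clearly more compound, so the chloro group alone does not fix the number seen for compound 2. Compound 4 gives no number, only a limit, so the full size of this step remains unknown: the limit of > 285000 nM in this assay, at which 1 of the 4 values shown sits.

The compounds shown leave open whether an ethyl group, an amine or a carboxylic acid on this aromatic carbon would move the read-out in the same direction as methyl. They also leave open whether methyl here would matter at all with fluoro or methoxy in place of chloro, since compounds 1 and 3 themselves stop at limits.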